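Swapping Fluoro for Hydroxy in a Small Series

The source may hold more compounds than are shown below. What is called first, only, known or untested is meant among the compounds shown, and "the series" means these compounds.

Values in a functional assay on MCF7 cells (Homo sapiens) for inhibition, read by MTT assay, with a stated time of 72 h; on this read-out lower numbers stand for stronger inhibition and higher numbers for weaker inhibition:
- compound 1 `COc1ccc(-c2nnc(SCCCN3CCN(c4nc5ccccc5s4)CC3)o2)cc1`: 171000 nM
- compound 2 `Cc1ccc(-c2nnc(SCCCN3CCN(c4nc5ccccc5s4)CC3)o2)cc1`: 107000 nM
- compound 3 `Fc1ccc(-c2nnc(SCCCN3CCN(c4nc5ccccc5s4)CC3)o2)cc1`: 84100 nM

Compound 3 reads 84100 nM in this assay. Its closest neighbour is compound 2, and the two cannot be told apart, with a 1.3-fold lower number from compound 2 to compound 3 (0.10 log units; within the scatter). The gap to compound 1 is wider, at a 2.0-fold lower number from compound 1 to compound 3 (0.31 log units; beyond the scatter).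

Compound 4 `Oc1ccc(-c2nnc(SCCCN3CCN(c4nc5ccccc5s4)CC3)o2)cc1` keeps the shared core and changes one group: hydroxy in place of fluoro on an aromatic carbon. This puts hydroxy in place of fluoro on an aromatic carbon, turning 4-fluorophenyl into 4-hydroxyphenyl.

For the measured compounds named here, no measured compound carries hydroxy, so the evidence is indirect. Three swaps at this place have been measured. Besides the two steps above, there is a 1.6-fold lower number from compound 1 to compound 2 (0.20 log units; within the scatter). Going by the values given here, only the step to compound 3 from compound 1 passes the scatter, and it is modest. The nearest measured group is the methoxy of compound 1, at 171000 nM, so a small move back toward that number seems the likeliest outcome, though the data cannot exclude a larger one.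

For compound 4 the estimated step is a 1.3-fold higher number from compound 3 to compound 4 (0.12 log units; within the scatter). Compound 4 is expected at about 110000 nM, with an estimated range of 50000 nM to 230000 nM.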

Compound 4, half-maximal inhibitory concentration: 81900 nM
The estimate for compound 4 lay 1.3-fold (0.13 log units) above the measured number; measured number inside the range.
By their numbers in this assay, from the lowest: compounds 4, 3, 2 and 1 (each within the scatter of the next, the first and the last beyond it).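

In this assay, for the compounds shown here, hydroxy is the first group here to bring a hydrogen-bond donor to this aromatic carbon, yet putting it in place of fluoro leaves the two compounds indistinguishable (a 1.0-fold lower number from compound 3 to compound 4 (0.01 log units; within the scatter)), and the same holds for hydroxy in place of methyl (a 1.3-fold lower number from compound 2 to compound 4 (0.12 log units; within the scatter)). Taking the methyl off the oxygen of compound 1 gives a modest step that does pass the scatter (a 2.1-fold lower number from compound 1 to compound 4 (0.32 log units; beyond the scatter)), so compound 1 now stands apart from both the fluoro and the hydroxy compounds, though not from the methyl compound 2. The series therefore tolerates a donor at this position with no detectable change from fluoro, but no measurement on hand explains why the number stays where it is.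

On these data alone, whether an amine or a carboxylic acid on this aromatic carbon would shift the number further remains open, as does the result of moving the hydroxy elsewhere on the ring. Also open, as far as these compounds go, is what a change to the shared core would do, since all four compounds carry it unaltered.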